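The compounds below may be only part of what the source reports. "The series", "measured", "known", "first", "only" and "open" are said of these compounds alone.

Of the compounds shown here, three of a shared core have been measured in an assay on cells for displacement of a labelled ligand from Neuronal acetylcholine receptor; alpha3/beta4 (Homo sapiens); on this read-out lower numbers stand for stronger inhibition and higher numbers for weaker inhibition. Compound 1 `O=C(Nc1cccc(F)c1)c1cncc(N2CC3CC(C2)N3)c1` gives 28 nM in this assay, the lowest number among the three. Compound 3 `O=C(c1cncc(N2CC3CC(C2)N3)c1)N1CCCc2ccccc21` gives 62 nM in this assay, a step from compound 1 that lies beyond the scatter. Compound 2 `COc1cc(NC(=O)c2cncc(N3CC4CC(C3)N4)c2)cc(OC)c1` gives 2000 nM in this assay, far above compound 1 and the weakest of the set.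

Compound 4 `O=C(Nc1ccc(Cl)cc1)c1cncc(N2CC3CC(C2)N3)c1` has not yet been measured. It differs from compound 1 in one place: 4-chlorophenyl in place of 3-fluorophenyl on an amide-type nitrogen. For the measured compounds named here, no measured pair shows this change, so its effect is unknown; what is known is only that an aryl amide of this core can sit anywhere from the number of compound 1 to the number of compound 2.

An exchange of one halogenated phenyl for another is expected to leave the number near that of compound 1, and the step from compound 1 to compound 4 is estimated as a 1.4-fold higher number from compound 1 to compound 4 (0.15 log units; within the scatter), within or only just beyond the scatter. Compound 4 is therefore expected at 40 nM in this assay, with a range from 12 nM to 130 nM.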

Compound 4, inhibition constant: 123 nM
The estimate for compound 4 lay 3.1-fold (0.49 log units) below the measured number, and the stated range covers the measured number.
By their numbers in this assay, from the lowest: compound 1; then compounds 3 and 4 (each within the scatter of the next); then compound 2.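

In this assay, placing 4-chlorophenyl in place of 3-fluorophenyl on the amide-type nitrogen gives a 4.4-fold higher number from compound 1 to compound 4 (0.64 log units; beyond the scatter). This single-place step shows that the position is not indifferent to which halogenated phenyl it carries, although both groups have the same count of heavy atoms and neither has a hydrogen-bond donor or acceptor. No measurement at hand bears on the reason for this step.

Halogen and ring position changed together, so the compounds shown leave open which of the two carries the step; a fluorophenyl with its fluorine placed where compound 4 has chlorine would separate them. They also leave open how an unsubstituted phenyl or a pyridyl group on that nitrogen would compare.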